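The compounds below may be only part of what the source reports. "The series", "measured", "known", "first", "only" and "open" are said of these compounds alone.

Measured so far:
compound 1, `CC1=C(C(=O)OC(C)(C)C)C(c2ccco2)NC(=O)N1C` — 26%
compound 2, `CC1=C(C(=O)OCc2ccccc2)C(c2ccco2)NC(=O)N1C` — 41%

In an assay on membranes from HEK293 cells for displacement of a labelled ligand from adenosine receptor A2b (Homo sapiens), read by scintillation counting, with a stated time of 30 min, tested at 1 uM (on this read-out higher numbers stand for more inhibition at the one concentration tested (going by the name of the read-out) and lower numbers for less inhibition), compound 1 gives 26%, the lowest of the two numbers. Nearest stands compound 2, which in this assay gives 41%; the single measured step, a number 15 percentage points higher from compound 1 to compound 2 (beyond the scatter), lies beyond the scatter and concerns only the group on the oxygen next to a carbonyl group.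

Compound 3, `CC1=C(C(=O)OC(C)(C)C)C(c2ccsc2)NC(=O)N1C`, is not yet measured. It differs from compound 1 in one place: thiophen-3-yl in place of furan-2-yl on a saturated ring carbon. For the measured compounds named here, no measured step touches the group on the saturated ring carbon, so the one step in hand, a number 15 percentage points higher from compound 1 to compound 2 (beyond the scatter), gives no direct guidance here; it shows only that a single change elsewhere in the shared core can move this assay by a modest amount. With the tert-butoxycarbonyl group of compound 1 kept, the expectation for compound 3 is a number close to compound 1, without a step beyond the scatter in either direction: the estimated step is a number 4 percentage points higher from compound 1 to compound 3 (within the scatter). Compound 3 is therefore estimated at 30%, with a range from 12% to 50%.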

Compound 3, a percentage reported as inhibition, at one concentration (the size of the read-out at that concentration, not a potency): 35%
Estimate against measurement, compound 3: 5 percentage points below, and the stated range covers the measured number.
By their numbers in this assay, from the lowest: compounds 1, 3 and 2 (each within the scatter of the next, the first and the last beyond it).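

In this assay, the first change shown on the saturated ring carbon gives a number 9 percentage points higher from compound 1 to compound 3 (within the scatter), so with the tert-butoxycarbonyl group kept, this read-out does not separate furan-2-yl from thiophen-3-yl at this position. For the compounds shown here, the swap keeps the counts of heavy atoms, donors and acceptors and the five-membered aromatic ring, but it replaces the ring oxygen with sulfur and also changes the ring position named in the group, and the single step cannot divide its size between these two differences. Nothing measured here bears on the origin of this step.

The compounds shown leave open whether furan-3-yl or thiophen-2-yl, each of which would separate the hetero atom from the ring position, would read any differently, and whether a larger change on the saturated ring carbon, such as phenyl or cyclohexyl, would move the number beyond the scatter. Also open, as far as these compounds go, is whether the benzyl group, which gave a number 15 percentage points higher from compound 1 to compound 2 (beyond the scatter) with furan-2-yl in place, would give a step of similar size with thiophen-3-yl on the saturated ring carbon.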